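Ketone aryl swap: amino out, methyl back in

The compounds below may be only part of what the source reports. "The series", "measured", "known", "first", "only" and "open" are said of these compounds alone.

Among the compounds with values here, in a functional assay on MDA-MB-231 cells (Homo sapiens) for cytotoxicity, read by MTT assay, with a stated time of 48 h (a lower number here means a stronger inhibitor, a higher number a weaker inhibitor), compound 2 `Nc1ccc(C(=O)/C=C/c2ccc3c(c2)B(O)OC3)cc1` gives 25800 nM, the highest of the two numbers so far; compound 1 `Cc1ccc(C(=O)/C=C/c2ccc3c(c2)B(O)OC3)cc1` gives 6500 nM. Within the data shown here, the only measured step bearing on the next change is a 4.0-fold higher number from compound 1 to compound 2 (0.60 log units; beyond the scatter), a modest loss on going from methyl to amino. Compound 3 `Cc1cccc(C(=O)/C=C/c2ccc3c(c2)B(O)OC3)c1` differs from compound 2 by 3-methylphenyl in place of 4-aminophenyl on a carbonyl carbon, restoring a methyl substituent as 3-methylphenyl rather than 4-methylphenyl. Because a 4.0-fold higher number from compound 1 to compound 2 (0.60 log units; beyond the scatter) was modest, a step of similar size in the opposite direction is expected, a 3.4-fold lower number from compound 2 to compound 3 (0.54 log units; beyond the scatter). Compound 3 is therefore estimated at 7500 nM, with a range from 3000 nM to 20000 nM.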

Compound 3, half-maximal inhibitory concentration: 4500 nM
Estimate against measurement, compound 3: 1.7-fold (0.22 log units) above; the range from low to high includes it.
By their numbers in this assay, from the lowest: compounds 3 and 1 (each within the scatter of the next); then compound 2.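

The change gives a 5.7-fold lower number from compound 2 to compound 3 (0.76 log units; beyond the scatter) in this assay, so the gain seen on replacing 4-aminophenyl holds with the methyl in a second placement. Moving between the two methylphenyl groups on the carbonyl carbon gives a 1.4-fold lower number from compound 1 to compound 3 (0.16 log units; within the scatter), so this pair cannot be told apart in this read-out. No measurement here accounts for the difference between the amino and methyl compounds.

Still open, from the compounds shown here alone, is how an unsubstituted phenyl, a methoxyphenyl or a carboxyphenyl would compare with the methylphenyl pair. Step 2>3 changes both group and placement, so the shown compounds do not separate amino's effect from its placement.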